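Swapping a nitrile for a chlorophenyl at the same aromatic position

The source may hold more compounds than are shown below. What is called first, only, known or untested is meant among the compounds shown, and "the series" means these compounds.

Measured compounds:
Compound 1, `Fc1ccc(CNc2nc(-c3ccccc3C(F)(F)F)nc3ccccc23)cc1`, gives 3400 nM in an assay on a protein complex for inhibition of ubiquitin carboxyl-terminal hydrolase 1/WD repeat-containing protein 48 (Homo sapiens), read by fluorescence; a higher number here means a weaker inhibitor, a lower number a stronger inhibitor.
Compound 2, `FC(F)(F)c1ccccc1-c1nc(NCc2ccc(Cl)cc2)c2ccccc2n1`, gives 4800 nM in this assay.
Compound 3, `N#Cc1ccc(CNc2nc(-c3ccccc3C(F)(F)F)nc3ccccc23)cc1`, gives 5700 nM in this assay.

All three share one core and differ only in the group on a single aromatic carbon of the outer ring. Compound 3 carries the highest number of the three, yet its distance from compound 2 and from compound 1 stays within the scatter, so none of the three can be called stronger or weaker than another.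

Compound 4, `FC(F)(F)c1ccccc1-c1nc(NCc2ccc(-c3cccc(Cl)c3)cc2)c2ccccc2n1`, is not yet measured. It differs from compound 3 in one place: 3-chlorophenyl in place of cyano on an aromatic carbon.

Among the measured compounds shown here, the steps that bear on this change are a 1.4-fold higher number from compound 1 to compound 2 (0.15 log units; within the scatter), a 1.7-fold higher number from compound 1 to compound 3 (0.22 log units; within the scatter) and a 1.2-fold higher number from compound 2 to compound 3 (0.07 log units; within the scatter). All three exchange one small group for another at the same carbon, and all three stay within the scatter. For the measured compounds named here, the change to compound 4 is of a different kind, since a whole aromatic ring enters where a two-atom group left, and no measured pair shows such an exchange. Compound 4 is therefore expected to stay close to compound 3, with a step of a 1.3-fold lower number from compound 3 to compound 4 (0.10 log units; within the scatter) and a wide margin on either side. The estimate for compound 4 is 4500 nM, between 1200 nM and 18000 nM.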

Compound 4, half-maximal inhibitory concentration: 2700 nM
Beside the measured number, compound 4's estimate is 1.7-fold (0.22 log units) above it; low and high end bracket the measured number.
By their numbers in this assay, from the lowest: compounds 4, 1, 2 and 3 (each within the scatter of the next, the first and the last beyond it).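

Among the compounds shown here, the earlier compounds only exchanged small groups at this aromatic carbon, so compound 4 is the first to show that a whole aromatic ring can sit here without a loss of inhibition in this assay. Set against the nitrile, the 3-chlorophenyl group gives a 2.1-fold lower number from compound 3 to compound 4 (0.32 log units; beyond the scatter), a modest change but the only step among these compounds that lies beyond the scatter. Against the chloro and fluoro groups, the same exchange gives a 1.8-fold lower number from compound 2 to compound 4 (0.25 log units; within the scatter) and a 1.3-fold lower number from compound 1 to compound 4 (0.10 log units; within the scatter), both within the scatter, so compound 4 cannot be separated from those two, and only the nitrile of compound 3 stands apart from it.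

No measurement given here explains the step from the nitrile to the 3-chlorophenyl group. From the compounds shown here alone, it also remains open whether the chlorine on the added ring matters, which a plain phenyl ring at the same carbon would test, and whether this position would accept a ring carrying an amine or a carboxylic acid, or a longer chain in place of a ring.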